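Swapping pyridin-3-yl for pyridin-4-yl in compound 2

The source may hold more compounds than are shown below. What is called first, only, known or untested is meant among the compounds shown, and "the series" means these compounds.

In a functional assay on HepG2 cells (Homo sapiens) for cytotoxicity, read by MTT assay, with a stated time of 24 h (on this read-out higher numbers stand for weaker inhibition and lower numbers for stronger inhibition), compound 1 `O=C1/C(=C/c2cccnc2)CN(S(=O)(=O)c2ccccc2)C/C1=C\c1ccccc1F` gives 8210 nM and compound 2 `O=C1/C(=C/c2cccnc2)CN(S(=O)(=O)c2ccc(C(F)(F)F)cc2)C/C1=C\c1ccccc1F` gives 2400 nM, the lower of the two numbers. For the measured compounds named here, the only measured step is a 3.4-fold lower number from compound 1 to compound 2 (0.53 log units; beyond the scatter), a modest one beyond the scatter, made by trifluoromethyl in place of hydrogen on an aromatic carbon. Compound 3 `O=C1/C(=C/c2ccncc2)CN(S(=O)(=O)c2ccc(C(F)(F)F)cc2)C/C1=C\c1ccccc1F` keeps that trifluoromethyl and differs from compound 2 in one place: pyridin-4-yl in place of pyridin-3-yl on a double-bonded chain carbon bound to a double-bonded ring carbon. Here pyridin-4-yl stands in place of pyridin-3-yl on a double-bonded chain carbon bound to a double-bonded ring carbon, with the same atoms joined differently. The measured step concerns another group, so it gives no direction for this swap. The expectation therefore starts from compound 2 at 2400 nM, and no step beyond the scatter is expected. The estimated step is a 1.0-fold lower number from compound 2 to compound 3 (0.02 log units; within the scatter). In this assay, the expected value for compound 3 is 2300 nM, within a range of 1000 nM to 5500 nM.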

Compound 3, half-maximal inhibitory concentration: 4030 nM
The estimate for compound 3 lay 1.8-fold (0.24 log units) below the measured number, within the range that was stated.
By their numbers in this assay, from the lowest: compounds 2 and 3 (each within the scatter of the next); then compound 1.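

In this assay, pyridin-4-yl in place of pyridin-3-yl on a double-bonded chain carbon bound to a double-bonded ring carbon gives a 1.7-fold higher number from compound 2 to compound 3 (0.23 log units; within the scatter) and so does not separate the two pyridine attachments at this place. For the compounds shown here, this is the first information about this place, as the earlier step concerned trifluoromethyl in place of hydrogen elsewhere in the molecule, and it shows that joining the same atoms differently here, with the trifluoromethyl kept, leaves the number within the scatter. No measurement is available that would explain this result.

The compounds shown leave open whether pyridin-2-yl, or a ring carrying a carboxylic acid, at this same place would also stay within the scatter of compound 2. Going by these compounds, whether this swap would behave the same way without the trifluoromethyl also remains open.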